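Pyridin-4-yl to 3-Methylphenyl: What to Expect for Compound 4

The source may report more compounds than this note shows. Statements on the series, on what has been measured and on what is new or still open speak of the compounds shown alone.

Measured compounds:
Compound 1 `CS(=O)(=O)c1ccc(-c2cnc3[nH]cc(-c4nnc(-c5ccncc5)o4)c(=O)c3c2)cc1` gives 29.2% in a functional assay on HCT-116 cells (Homo sapiens) for positive allosteric modulation, read by MTT assay, with stated times of 24 h and 48 h, tested at 2.5 uM; on this read-out lower numbers stand for less inhibition of growth and higher numbers for more inhibition of growth at the one concentration tested.
Compound 2 `O=c1c(-c2nnc(-c3ccc(Cl)cc3)o2)c[nH]c2ncc(-c3cccnc3)cc12` gives 20.1% in this assay.
Compound 3 `O=c1c(-c2nnc(-c3ccc(Cl)cc3)o2)c[nH]c2ncc(-c3ccccc3)cc12` gives 29.8% in this assay.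

Among these three numbers compound 1 stands second highest. Its nearest neighbour is compound 3, whose value sits only a fraction of a point higher, and its furthest is compound 2, about nine points lower; both gaps lie within the scatter, so no order can be read among them.

Compound 4 `Cc1cccc(-c2nnc(-c3c[nH]c4ncc(-c5ccc(S(C)(=O)=O)cc5)cc4c3=O)o2)c1` is the unmeasured partner of compound 1. The change is 3-methylphenyl in place of pyridin-4-yl on an aromatic carbon.

Going by the values given here, one measured step bears on this: a number 9.7 percentage points higher from compound 2 to compound 3 (within the scatter), where a ring nitrogen was likewise dropped from the aryl group on this arm, though at a different position and without a methyl. That step stayed within the scatter. Compound 4 therefore is expected to move little from compound 1 in this assay, with a number 3.8 percentage points higher from compound 1 to compound 4 (within the scatter) as the estimated step, perhaps a touch upward, but nothing beyond the scatter.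

The estimate for compound 4 is 33%, expected to fall between 19% and 47%.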

Compound 4, percent growth inhibition at one concentration: 50.8%
Beside the measured number, compound 4's estimate is 17.8 percentage points below it; measured number above the stated range.
By their numbers in this assay, from the lowest: compounds 2, 1 and 3 (each within the scatter of the next); then compound 4.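

The step at this place is the first one among the compounds shown to clear the usual scatter: in this assay there is a number 21.6 percentage points higher from compound 1 to compound 4 (beyond the scatter). It shows that the group on the aromatic carbon of the five-membered ring, next to the ring nitrogen and the ring oxygen, can shift growth inhibition at the one concentration tested, with the rest of compound 1 left unchanged. The earlier step, a number 9.7 percentage points higher from compound 2 to compound 3 (within the scatter), lies at a different place and stays within the scatter, so it gave no sign of this, and no measurement here offers an explanation for the rise.

The change from pyridin-4-yl to 3-methylphenyl removes a ring nitrogen and adds a methyl in a single step, leaving open which of the two goes with the higher number, or whether both are needed. On these data alone, it is also open whether a methoxy group or an amine in place of that methyl would keep growth inhibition near the level of compound 4 at 50.8%.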